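Thiazole for Dimethylfuran on an Acetamido Core

The compounds below may be only part of what the source reports. "The series", "measured", "known", "first", "only" and "open" are said of these compounds alone.

Compound 1 `Cc1cc(C(=O)Nc2cccc(-c3ccnc4c(N)cccc34)c2)c(C)o1` carries a 2,5-dimethylfuran-3-yl amide on a core bearing an amino group. In a functional assay on A375P cells (Homo sapiens) for antiproliferative activity, read by MTT assay, with a stated time of 48 h (a higher number here means a weaker inhibitor, a lower number a stronger inhibitor), compound 1 gives only a limit of the assay, > 20000 nM. Compound 2 `Nc1cccc2c(-c3cccc(NC(=O)c4nccs4)c3)ccnc12` differs by 1,3-thiazol-2-yl in place of 2,5-dimethylfuran-3-yl on a carbonyl carbon, and in this assay compound 2 gives 16700 nM. That change made an at least 1.1-fold lower number from compound 1 to compound 2 (0.07 log units; that floor lies within the scatter), which the floor at the limit of > 20000 nM in this assay, at which 2 of the 3 values shown sit, keeps from being read more closely. Compound 3 `CC(=O)Nc1cccc2c(-c3cccc(NC(=O)c4cc(C)oc4C)c3)ccnc12` differs from compound 1 by acetyl in place of hydrogen on a nitrogen on an aromatic ring, and a step that the two limits leave unreadable from compound 1 to compound 3 is the outcome of that core change. In this assay compound 3 gives only a limit of the assay, > 20000 nM. Compound 4 `CC(=O)Nc1cccc2c(-c3cccc(NC(=O)c4nccs4)c3)ccnc12`, not yet measured, stands to compound 3 as compound 2 stands to compound 1: the change is 1,3-thiazol-2-yl in place of 2,5-dimethylfuran-3-yl on a carbonyl carbon, at the same place, and so is the same change. He expects it to make about a number no higher from compound 3 to compound 4 (the limit leaves the size open), resting on compound 1 and compound 2, whose step was an at least 1.1-fold lower number from compound 1 to compound 2 (0.07 log units; that floor lies within the scatter) and whose reading is bounded by the limit of > 20000 nM in this assay, at which 2 of the 3 values shown sit. Compound 4 is therefore estimated at 20000 nM, likely between 8000 nM and 45000 nM, with a fair chance that only a limit is reported.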

Compound 4, half-maximal inhibitory concentration: > 20000 nM
Compound 4 was reported as a limit; the forecaster's own chance of this, stated with the estimate: 50%; the middle value lies on the limit itself.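

In this assay compound 4 gives only a limit of the assay, > 20000 nM, so the change from 2,5-dimethylfuran-3-yl to 1,3-thiazol-2-yl on the core of compound 3 yields no measured number. Among the compounds shown here, the step between compound 3 and compound 4 cannot be read, nor can the one between compound 1 and compound 3, so the data neither show that the change carries over from the core of compound 1 to the core of compound 3 nor show that it fails to, and what bounds the reading is this: the limit of > 20000 nM in this assay, at which 3 of the 4 values shown sit. For the compounds shown here, the one readable new step, the acetyl change on the nitrogen, is an at least 1.1-fold higher number from compound 2 to compound 4 (0.07 log units; that floor lies within the scatter), which gives only a floor and leaves the true size of the step open.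

On these data alone, whether a propanoyl group in place of the acetyl would give a value that can be read remains open. The same holds for a pyridin-2-yl or a morpholine group in place of the 1,3-thiazol-2-yl on the carbonyl carbon.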